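Sulfone series: thiazolyl for methoxyphenyl on the aryl sulfone

A few compounds are considered here, and "the series" means these few. Any claim that something is new, unique, unknown or untested is made for them only; others in the source may bear on it.

Working notes on the shared core of compound 1 `COc1ccc(S(=O)(=O)c2ccc(NC(=O)C(C)(O)C(F)(F)F)cc2)cc1`. In a functional assay (Cavia porcellus) with sulfonylurea receptors; K-ATP channels (Homo sapiens) as the target (on this read-out lower numbers stand for stronger inhibition and higher numbers for weaker inhibition), compound 1 gives only a limit of the assay, > 30000 nM. Compound 2 `CC(O)(C(=O)Nc1ccc(C(=O)c2cccc(F)c2)cc1)C(F)(F)F` gives a number, 2600 nM in this assay. Compound 3 `CC(O)(C(=O)Nc1ccc(C(=O)c2ccccc2)cc1Br)C(F)(F)F` reaches only a limit of the assay, > 30000 nM in this assay. Going by the values given here, two of the three values shown thus sit at the same point, which is the limit of > 30000 nM in this assay, at which 2 of the 3 values shown sit; compound 1 stands there, with no number of its own, and compound 2 is the only compound of the three that gives a measured value.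

The unmeasured compound 4 `CC(O)(C(=O)Nc1ccc(S(=O)(=O)c2cncs2)cc1)C(F)(F)F` differs from compound 1 in one place: 1,3-thiazol-5-yl in place of 4-methoxyphenyl on a sulfonyl sulfur. Among the compounds with values here, no step between two measured compounds is known, so the size of this change cannot be read from any measured pair. Within the data shown here, the only number at hand, that of compound 2, comes from a ketone rather than a sulfonyl compound, and no measured step connects it to compound 1.

With the starting point at a limit, the step from compound 1 to compound 4 is expected as an at least 1.5-fold lower number from compound 1 to compound 4 (0.17 log units; that floor lies within the scatter), toward a somewhat lower number. Compound 4 is expected to give about 20000 nM in this assay, within 5000 nM to 60000 nM, and a limit rather than a number remains quite possible.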

Compound 4, half-maximal inhibitory concentration: 7700 nM
Estimate against measurement, compound 4: 2.6-fold (0.41 log units) above; the range from low to high includes it.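

With 1,3-thiazol-5-yl in place of 4-methoxyphenyl on a sulfonyl sulfur, this assay shows an at least 3.8-fold lower number from compound 1 to compound 4 (0.59 log units; beyond the scatter), so the group on this sulfur can move the read-out by more than the usual scatter. Compound 4 gives 7700 nM, the first number shown for a sulfonyl compound of the series. On these data alone, the true size of the step remains unknown. Compound 1 stands at a limit of the assay, not at a number: the limit of > 30000 nM in this assay, at which 2 of the 4 values shown sit.

The compounds shown leave open whether the lower number comes from the presence of 1,3-thiazol-5-yl or from the loss of 4-methoxyphenyl, since a single replacement cannot separate the two; an unsubstituted phenyl, a pyridine ring or an amine on the sulfonyl sulfur would help to tell them apart. They also leave open whether 1,3-thiazol-5-yl would have any comparable effect in the ketone compounds, and how far the number can fall at this place on the sulfonyl sulfur.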